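The source may hold more compounds than are shown below. What is called first, only, known or untested is meant among the compounds shown, and "the series" means these compounds.

Among the compounds with values here, compound 2 `O=C(/C=C/c1ccc2c(c1)B(O)OC2)c1ccc(Br)cc1` holds the only plain number in a toxicity assay on WI-38 cells (Homo sapiens) for cytotoxicity, read by MTT assay, with a stated time of 48 h (on this read-out higher numbers stand for weaker inhibition and lower numbers for stronger inhibition), where compound 2 gives 36700 nM. The remaining value is a limit: compound 1 `Cn1cccc1C(=O)/C=C/c1ccc2c(c1)B(O)OC2` gives > 100000 nM in this assay, namely (the limit of > 100000 nM in this assay, at which 1 of the 2 values shown sits). Compound 3 `O=C(/C=C/c1ccc2c(c1)B(O)OC2)c1ccccc1F` differs from compound 2 by 2-fluorophenyl in place of 4-bromophenyl on a carbonyl carbon. Within the data shown here, only one measured step touches this carbonyl position, and it swaps a different pair of groups: an at least 2.7-fold lower number from compound 1 to compound 2 (0.43 log units; beyond the scatter). Among the measured compounds shown here, no measured step exchanges 4-bromophenyl for 2-fluorophenyl, so no shift beyond the scatter is expected. Compound 3 is estimated at 55000 nM in this assay, between 20000 nM and 150000 nM, with an expected step of a 1.5-fold higher number from compound 2 to compound 3 (0.18 log units; within the scatter).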

Compound 3, half-maximal inhibitory concentration: 23600 nM
Compound 3: middle estimate off by 2.3-fold (0.37 log units), on the high side, within the range that was stated.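

On the carbonyl carbon, 2-fluorophenyl and 4-bromophenyl are not told apart in this assay: a 1.6-fold lower number from compound 2 to compound 3 (0.19 log units; within the scatter). A second halogenated phenyl group now shows the shift away from 1-methyl-1H-pyrrol-2-yl, with an at least 4.2-fold lower number from compound 1 to compound 3 (0.62 log units; beyond the scatter). That step starts from a limit and not from a number: the limit of > 100000 nM in this assay, at which 1 of the 3 values shown sits.

The compounds shown leave open how a phenyl group carrying an amine or a carboxylic acid would read here. They also cannot separate the halogen from its place on the ring, as 4-bromophenyl and 2-fluorophenyl differ in both at once.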